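Series notes: cyano in place of hydrogen, compound 3 to 4

The compounds below may be only part of what the source reports. "The series", "measured", "known", "first", "only" and "open" are said of these compounds alone.

In an assay on cells for inhibition of Amine oxidase [flavin-containing] A (Homo sapiens), read by fluorescence and spectrophotometry, using microsomes, with a stated time of 20 min (a higher number here means a weaker inhibitor, a lower number a stronger inhibitor), compound 1 `NS(=O)(=O)c1ccc(C(=O)NNC(=O)c2ccccc2)cc1` gives 62800 nM. Compound 2 `NS(=O)(=O)c1cc(-c2nnc(-c3ccccc3)o2)ccc1Cl` returns only a limit in this assay, > 100000 nM. That reading is the limit of > 100000 nM in this assay, at which 1 of the 3 values shown sits. Compound 3 `NS(=O)(=O)c1ccc(-c2nnc(-c3ccccc3)o2)cc1` gives 63900 nM in this assay; it stands with compound 1, the two numbers lying within the scatter of each other, so no order between them can be claimed. Compound 4 `N#Cc1ccc(-c2nnc(-c3ccc(S(N)(=O)=O)cc3)o2)cc1` is not yet measured; it differs from compound 3 by cyano in place of hydrogen on an aromatic carbon. Going by the values given here, no measured pair shows this change, so there is no step to lean on. The expectation is a step from compound 3 to compound 4 of a 1.1-fold lower number from compound 3 to compound 4 (0.03 log units; within the scatter), not beyond the scatter in either direction. Compound 4 is thus estimated at 60000 nM, within 25000 nM to 150000 nM.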

Compound 4, half-maximal inhibitory concentration: 24300 nM
For compound 4 the middle estimate is 2.5-fold (0.39 log units) above the measured one; measured number outside the range, below it.
By their numbers in this assay, from the lowest: compound 4; then compounds 1 and 3 (each within the scatter of the next). At a limit, above all of these: compound 2.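

In this assay, cyano in place of hydrogen on an aromatic carbon, para to a large group, gives a 2.6-fold lower number from compound 3 to compound 4 (0.42 log units; beyond the scatter). Going by these compounds alone, this is the first sign that the series responds to a change at this position, and the number moves downward with the added cyano. Nothing measured here bears on the reason for this step.

This single pair gives one step and no trend across groups. Going by these compounds, whether the step is specific to cyano remains open, and an amine, a methoxy group or a carboxylic acid at the same position would test this.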